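Taking the hydroxy group away from compound 1

The source may report more compounds than this note shows. Statements on the series, on what has been measured and on what is new or still open speak of the compounds shown alone.

Measured in a physicochemical assay for solubility, read by spectrophotometry, using the shake flask method, with a stated time of 2 days, at pH 6.5; on this read-out higher numbers stand for higher solubility and lower numbers for lower solubility:
- compound 1 `O=C(O)COc1ccc2nc(-c3cn(-c4ccc(O)cc4)nn3)ccc2c1`: 365 ug/mL
- compound 2 `Oc1ccc(-n2cc(-c3ccc4cc(OCC5CCCCO5)ccc4n3)nn2)cc1`: 3.4 ug/mL
- compound 3 `Oc1ccc(-n2cc(-c3ccc4ccccc4n3)nn2)cc1`: 2.2 ug/mL

Compound 1 stands highest of the three, with a 110-fold lower number from compound 1 to compound 2 (2.03 log units; beyond the scatter) and a 170-fold lower number from compound 1 to compound 3 (2.22 log units; beyond the scatter). Between the other two lies a 1.5-fold lower number from compound 2 to compound 3 (0.19 log units; within the scatter). Compound 4 `O=C(O)COc1ccc2nc(-c3cn(-c4ccccc4)nn3)ccc2c1` keeps the carboxymethoxy group of compound 1 and differs elsewhere: hydrogen in place of hydroxy on an aromatic carbon. In words, this is hydrogen in place of hydroxy on an aromatic carbon. Going by the values given here, no measured step touches that place, since all three concern the carboxymethoxy position, so they bear on it only indirectly. Without a direct precedent, a modest drop is expected, far smaller than a 170-fold lower number from compound 1 to compound 3 (2.22 log units; beyond the scatter). The expected step is a 1.7-fold lower number from compound 1 to compound 4 (0.22 log units; within the scatter). For compound 4 the estimated value is 220 ug/mL, with an expected range of 70 ug/mL to 500 ug/mL.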

Compound 4, solubility: 1050 ug/mL
Compound 4: middle estimate off by 4.8-fold (0.68 log units), on the low side; the measured number lies above the stated range.
By their numbers in this assay, from the lowest: compounds 3 and 2 (each within the scatter of the next); then compound 1; then compound 4.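

In this assay, going by these compounds alone, the change from 4-hydroxyphenyl to phenyl gives a 2.9-fold higher number from compound 1 to compound 4 (0.46 log units; beyond the scatter) and so shows that this place, which no earlier step touched, also moves the number, and moves it upward. That step is small beside a 170-fold lower number from compound 1 to compound 3 (2.22 log units; beyond the scatter) at the carboxymethoxy position. Nothing given here explains its direction.

As far as these compounds go, whether an amine or a methoxy group at this place would go the same way remains open. So does whether removing the hydroxy group would give a similar step in compound 2 or compound 3, which lack the carboxylic acid.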